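Replacing acetamido on the saturated ring carbon

The source may report more compounds than this note shows. Statements on the series, on what has been measured and on what is new or still open speak of the compounds shown alone.

In an ADME assay on cells (Hepatocyte, Mus musculus) for metabolic stability, with a stated time of 30 min (a higher number here means that more of the compound is left, a lower number that less of the compound is left), compound 1 `NC1CCC(CN2CCN(c3cc(=O)c4cc(C(F)(F)F)cc([N+](=O)[O-])c4s3)CC2)CC1` gives 107% and compound 2 `CC(=O)NC1CCC(CN2CCN(c3cc(=O)c4cc(C(F)(F)F)cc([N+](=O)[O-])c4s3)CC2)CC1` gives 94.9%, the lower of the two numbers. Compound 3 `COc1ccc(C(=O)OC2CCC(CN3CCN(c4cc(=O)c5cc(C(F)(F)F)cc([N+](=O)[O-])c5s4)CC3)CC2)cc1` carries ((4-methoxyphenyl)carbonyl)oxy in place of acetamido on a saturated ring carbon. Within the data shown here, the one measured step bearing on this is a number 12.1 percentage points lower from compound 1 to compound 2 (beyond the scatter), modest yet beyond the scatter, with acetyl in place of hydrogen on an amine nitrogen. Among the measured compounds shown here, no measured compound carries the entering group, so a somewhat larger downward step in this assay is expected, with wide uncertainty. The expected step is a number 19.9 percentage points lower from compound 2 to compound 3 (beyond the scatter). For compound 3 the estimate is 75%, in a range of 40% to 105%.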

Compound 3, percent of the compound remaining: 31%
The estimate for compound 3 lay 44 percentage points above the measured number; measured number outside the range, below it.
By their numbers in this assay, from the lowest: compound 3; then compound 2; then compound 1.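

In this assay, the substituent on the saturated ring carbon matters far more than the modest acetyl step suggested: ((4-methoxyphenyl)carbonyl)oxy gives a number 63.9 percentage points lower from compound 2 to compound 3 (beyond the scatter) and a number 76 percentage points lower from compound 1 to compound 3 (beyond the scatter), both large. This position therefore tolerates amino and acetamido with much of the compound left, but not this larger ester group. Nothing measured here explains the drop. As far as these compounds go, it remains open whether the step follows the ester link or the 4-methoxyphenyl ring; an amide bearing the same 4-methoxyphenyl carbonyl, or a simple acetate ester, would separate the two.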